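Permeability estimate for a pyridin-2-yl analogue of compound 1

The source may report more compounds than this note shows. Statements on the series, on what has been measured and on what is new or still open speak of the compounds shown alone.

Compound 1 `Cn1cc(C(=O)Nc2ccc(-c3ccccc3)c(C(F)(F)F)c2)c(=O)c2cnccc21` was tested in an ADME assay on LLC-PK1 cells (Sus scrofa) for permeability (on this read-out higher numbers stand for higher permeability and lower numbers for lower permeability), where compound 1 gives 5.7 10^-6 cm/s. Two related compounds sit alongside it. Compound 3 `Cn1cc(C(=O)Nc2cnc(-c3ccccc3)c(C(F)(F)F)c2)c(=O)c2ccccc21` gives 11 10^-6 cm/s in this assay, a number that lies within the usual scatter of compound 1 and so cannot be ranked against it. Compound 2 `Cn1cc(C(=O)Nc2ccc(-c3ccccc3)c(C(F)(F)F)c2)c(=O)c2ncccc21` gives 16 10^-6 cm/s, a number that stands beyond the scatter above compound 1, so compound 1 holds the lowest of the three numbers.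

Compound 4 `Cn1cc(C(=O)Nc2ccc(-c3ccccn3)c(C(F)(F)F)c2)c(=O)c2cnccc21` has not yet been measured. It differs from compound 1 in one place: pyridin-2-yl in place of phenyl on an aromatic carbon. Among the compounds with values here, no pair among the measured compounds shows this change, so there is no measured step to rest on. The expectation is a small downward shift, on the order of the usual scatter or slightly beyond it. The estimated value for compound 4 in this assay is 4 10^-6 cm/s, with a range from 2 10^-6 cm/s to 8 10^-6 cm/s, corresponding to an expected step of a 1.4-fold lower number from compound 1 to compound 4 (0.15 log units; within the scatter).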

Compound 4, apparent permeability in the LLC-PK1 assay: 16 10^-6 cm/s
Estimate against measurement, compound 4: 4.0-fold (0.60 log units) below; the measured number lies above the stated range.
By their numbers in the LLC-PK1 assay, from the lowest: compounds 1, 3, 2 and 4 (each within the scatter of the next, the first and the last beyond it).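

In the LLC-PK1 assay, pyridin-2-yl in place of phenyl on an aromatic carbon, ortho to a trifluoromethyl group, gives the first step measured at this place, a 2.8-fold higher number from compound 1 to compound 4 (0.45 log units; beyond the scatter), and it runs upward. In a physicochemical assay for solubility, at pH 7.4 (on this read-out lower numbers stand for lower solubility and higher numbers for higher solubility), compound 1 gives < 1 ug/mL, which is a limit of the assay and not a number. Within the data shown here, in the physicochemical assay compound 4 gives 120 ug/mL, so the same change goes with a higher number on both read-outs, which the earlier compounds, none of them differing from another in one place, could not show.

The compounds shown leave open whether a pyridin-3-yl or pyridin-4-yl group in this place would give the same picture on both read-outs. They also leave open how an amine or a carboxylic acid on the ring at this place would read.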